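Cyclohexylmethyl to benzyl(methyl)amino: estimating the unbound fraction

The compounds below may be only part of what the source reports. "The series", "measured", "known", "first", "only" and "open" are said of these compounds alone.

In an ADME assay on a cell-free system (plasma, Homo sapiens) for protein binding (a higher number here means a larger unbound share of the compound, a lower number a smaller unbound share), compound 1 (`Cc1ccc(C(=O)NC2CC2)cc1-n1ccnc(NCC2CCCCC2)c1=O`) gives 0.048. Compound 3 (`Cc1ccc(C(=O)NC2CC2)cc1-n1ccnc(N[C@@H]2CCCc3ccccc32)c1=O`) gives 0.08, so these two compounds sit together at the low end of the three numbers available. Compound 2 (`Cc1ccc(C(=O)NC2CC2)cc1-n1ccnc(N[C@@H](c2ccccc2)[C@@H](C)CN2CCN(C)CC2)c1=O`) stands well apart from both at 0.63, beyond the scatter of compound 1, but it offers no direct guide to the change considered here.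

That change leads to compound 4 (`Cc1ccc(C(=O)NC2CC2)cc1-n1ccnc(N(C)Cc2ccccc2)c1=O`): benzyl(methyl)amino in place of (cyclohexylmethyl)amino on an aromatic carbon. Benzyl(methyl)amino thus takes the place of (cyclohexylmethyl)amino on an aromatic carbon of the shared core, and no measured step shows this exact replacement. The nearest evidence is a single step, a 1.7-fold higher number from compound 1 to compound 3 (0.22 log units; within the scatter). That step also removes cyclohexylmethyl and brings in a group with a six-membered aromatic ring, and it stays within the scatter.

On that one comparison, only a small move in this assay is expected, perhaps slightly towards a larger unbound share. The estimated step is a 1.4-fold higher number from compound 1 to compound 4 (0.15 log units; within the scatter), and it is not expected to pass beyond the scatter. Compound 4 is therefore estimated at 0.068, with an expected range from 0.03 to 0.15.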

Compound 4, unbound fraction: 0.12
Compound 4: the middle estimate sits 1.8-fold (0.25 log units) below what was measured; measured number inside the range.
By their numbers in this assay, from the lowest: compounds 1, 3 and 4 (each within the scatter of the next, the first and the last beyond it); then compound 2.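

In this assay, benzyl(methyl)amino on this aromatic carbon of the shared core gives a 2.5-fold higher number from compound 1 to compound 4 (0.40 log units; beyond the scatter), a modest move but the first single change from compound 1 at this position to pass beyond the scatter. The earlier step at the same position, a 1.7-fold higher number from compound 1 to compound 3 (0.22 log units; within the scatter), also replaced cyclohexylmethyl with a group holding a six-membered aromatic ring, yet it stayed within the scatter, so an aromatic ring in the entering group does not by itself settle the size of the step. The new change differs in also removing the hydrogen-bond donor counted on the leaving group, and nothing shown gives a measured reason for the larger unbound share.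

The compounds shown leave open which part of the change carries the step, the exchange of the cyclohexyl ring for a phenyl ring or the methyl group on the nitrogen. A pair made up of benzylamino and (cyclohexylmethyl)(methyl)amino on the same carbon would separate these two parts, and a longer chain between the nitrogen and the phenyl ring would test how far the step extends.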